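Swapping a ring for ethynyl on an inactive scaffold

The source may report more compounds than this note shows. Statements on the series, on what has been measured and on what is new or still open speak of the compounds shown alone.

Compound 1 `Cc1nc(N)c2c(-c3ccoc3)cn([C@@H]3O[C@H](CO)[C@@H](O)[C@H]3O)c2n1`: > 20000 nM
Compound 2 `Cc1nc(N)c2c(-c3ccsc3)cn([C@@H]3O[C@H](CO)[C@@H](O)[C@H]3O)c2n1`: > 20000 nM
Compound 3 `Cc1nc(N)c2c(-c3ccccc3)cn([C@@H]3O[C@H](CO)[C@@H](O)[C@H]3O)c2n1`: > 20000 nM

These three compounds were tested in a functional assay on K562 cells (Homo sapiens), read by MTT assay, with a stated time of 72 h (on this read-out lower numbers stand for stronger inhibition and higher numbers for weaker inhibition), and share one core, differing only in the ring group on one aromatic carbon. In this assay compound 3 gives > 20000 nM, which is a limit of the assay and not a number. It has no exact place among its neighbours, and the record reads (the limit of > 20000 nM in this assay, at which 3 of the 3 values shown sit).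

Compound 4 `C#Cc1cn([C@@H]2O[C@H](CO)[C@@H](O)[C@H]2O)c2nc(C)nc(N)c12` carries ethynyl in place of phenyl on an aromatic carbon. The difference from compound 3 is ethynyl in place of phenyl on an aromatic carbon.

Three measured changes bear on this, all at the same carbon. They are a step that the two limits leave unreadable from compound 1 to compound 2, a step that the two limits leave unreadable from compound 1 to compound 3 and a step that the two limits leave unreadable from compound 2 to compound 3. None of them gives a size, and each exchanges one ring for another, whereas ethynyl has no ring. The data therefore give no firm direction. The most likely expectation is that compound 4 also stays at the limit, with some chance of a measurable value that shows stronger inhibition.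

Compound 4 is estimated at 20000 nM, with an expected range from 4000 nM to 50000 nM. The expected change is a number no higher from compound 3 to compound 4 (the limit leaves the size open).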

Compound 4, half-maximal inhibitory concentration: > 20000 nM
Compound 4: a limit, no number (the forecaster's own chance of this, stated with the estimate: 65%); the middle value sits exactly at the limit.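

In this assay compound 4 gives > 20000 nM, which is a limit of the assay and not a number. Its steps from compound 1, compound 2 and compound 3 therefore cannot be read, and all four compounds sit at the same limit: the limit of > 20000 nM in this assay, at which 4 of the 4 values shown sit.

The compounds shown leave open how the ring groups and ethynyl truly rank, since none has a measured number.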